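The source may hold more compounds than are shown below. What is called first, only, known or untested is meant among the compounds shown, and "the series" means these compounds.

Compound 1 `Nc1c(C2=NCCCN2)cnn1-c1ccccc1` gives > 500000 nM in an ADME assay on Vero cells (Chlorocebus sabaeus) for cytotoxicity, read by CellTiter-Glo and ATP content, with a stated time of 72 h (on this read-out lower numbers stand for higher toxicity in this test and higher numbers for lower toxicity in this test), which is a limit of the assay rather than a number.
Compound 2 `Nc1c(C2=NCCCN2)cnn1-c1ccc(F)cc1` gives > 500000 nM in this assay, likewise a limit.

On the numbers shown, compound 1 stands at the limit, where both values sit (the limit of > 500000 nM in this assay, at which 2 of the 2 values shown sit). Compound 3 `Nc1c(C2=NCCCN2)cnn1-c1cccc(Br)c1` differs from compound 1 by bromo in place of hydrogen on an aromatic carbon. Going by the values given here, the only measured step that bears on such a change is a step that the two limits leave unreadable from compound 1 to compound 2, and its size cannot be read. No movement beyond the scatter is therefore expected. Compound 3 is expected to show a number no higher from compound 1 to compound 3 (the limit leaves the size open). The estimate for compound 3 is 500000 nM, with a range from 150000 nM to 1000000 nM.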

Compound 3, half-maximal cytotoxic concentration: > 500000 nM
Compound 3 was reported as a limit; the forecaster's own chance of this, stated with the estimate: 80%; the middle value lies on the limit itself.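

The step from compound 1 to compound 3 cannot be read, since both results are limits rather than numbers: the limit of > 500000 nM in this assay, at which 3 of the 3 values shown sit.
In this assay the compounds shown leave open how far each lies beyond that limit, and whether fluoro or bromo in place of hydrogen changes the read-out at all.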